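The source may report more compounds than this note shows. Statements on the series, on what has been measured and on what is new or still open speak of the compounds shown alone.

In an ADME assay on HeLa cells (Homo sapiens) for cytotoxicity, read by MTT assay (a higher number here means a weaker inhibitor, a lower number a stronger inhibitor), compound 2 `COc1ccc(C[C@H]2COC(=O)[C@@H]2Cc2ccc(OCc3cn(-c4ccc(Br)cc4)nn3)c(OC)c2)cc1OC` gives 128000 nM while compound 1 `COc1ccc(C[C@H]2COC(=O)[C@@H]2Cc2ccc(OCc3cn(Cc4ccc(Cl)cc4)nn3)c(OC)c2)cc1OC` gives 242000 nM and compound 3 `CCN1CCN(C(=O)CCC(=O)Oc2ccc(C[C@H]3C(=O)OC[C@@H]3Cc3ccc(OC)c(OC)c3)cc2OC)CC1` gives 190000 nM as their readings. Compound 2 lies within the scatter of both, so it cannot be told apart from them. Compound 4 `COc1ccc(C[C@H]2COC(=O)[C@@H]2Cc2ccc(OCC(=O)N3CCCC3)c(OC)c2)cc1OC` keeps the core of compound 2 but carries (pyrrolidin-1-yl)carbonyl in place of 1-(4-bromophenyl)-1H-1,2,3-triazol-4-yl on a saturated chain carbon bound to an oxygen on an aromatic ring, a change counted as (pyrrolidin-1-yl)carbonyl in place of 1-(4-bromophenyl)-1H-1,2,3-triazol-4-yl on a saturated chain carbon bound to an oxygen on an aromatic ring in full. For the measured compounds named here, the one measured step that bears on it is a 1.9-fold lower number from compound 1 to compound 2 (0.28 log units; within the scatter) and it puts 4-bromophenyl in place of 4-chlorobenzyl on an aromatic nitrogen, a step within the scatter. Compound 3 has no such triazolyl group and still gives 190000 nM as its reading, level with compound 2. No step beyond the scatter is therefore expected, in either direction. The expected change is a 1.4-fold higher number from compound 2 to compound 4 (0.15 log units; within the scatter) and that stays within the scatter. Compound 4 is estimated at 180000 nM with an expected range from 90000 nM to 360000 nM as its reading.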

Compound 4, half-maximal inhibitory concentration: >= 600000 nM
Compound 4 was reported as a limit (the forecaster's own chance of this, stated with the estimate: 10%); at least 3.3-fold (0.52 log units) between middle value and limit.
By their numbers in this assay, from the lowest: compounds 2, 3 and 1 (each within the scatter of the next). At a limit, above all of these: compound 4.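

In this assay, replacing 1-(4-bromophenyl)-1H-1,2,3-triazol-4-yl with (pyrrolidin-1-yl)carbonyl on a saturated chain carbon bound to an oxygen on an aromatic ring gives an at least 4.6-fold higher number from compound 2 to compound 4 (0.67 log units; beyond the scatter) and is the first step shown to pass the scatter. The earlier step, a 1.9-fold lower number from compound 1 to compound 2 (0.28 log units; within the scatter), kept the triazole and changed only the group on its aromatic nitrogen, so it could not show what losing the whole group does. As far as these compounds go, compound 4 is reported only as a limit, so the full size of its step remains unknown: the limit of >= 600000 nM in this assay, at which 1 of the 4 values shown sits.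

From the compounds shown here alone, the triazole and bromophenyl leave while the carbonyl and pyrrolidine enter in one step, so which of these changes matters stays open. A carboxylic acid in that place, or a triazole carrying only a methyl group, would help separate them.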